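Ethoxy for methoxy in a dichlorophenyl-substituted core

The source may hold more compounds than are shown below. What is called first, only, known or untested is meant among the compounds shown, and "the series" means these compounds.

Measured compounds:
compound 1, `Cc1ccc(C[C@H]2COC(=O)[C@@H]2Cc2ccc(Cl)c(Cl)c2)cc1`, 19000 nM
compound 2, `CCc1ccc(C[C@H]2COC(=O)[C@@H]2Cc2ccc(Cl)c(Cl)c2)cc1`, 16000 nM
compound 3, `COc1ccccc1C[C@H]1COC[C@@H]1Cc1ccc(Cl)c(Cl)c1`, 55000 nM

Three compounds were tested in a functional assay on HL-60 cells (Homo sapiens) for cytotoxicity, read by WST assay, with a stated time of 48 h; on this read-out lower numbers stand for an effect already at smaller amounts and higher numbers for an effect only at larger amounts of compound. Compound 1 gives 19000 nM and compound 2 gives 16000 nM. The two differ only by methyl in place of hydrogen on a saturated chain carbon bound to an aromatic carbon, and the step of a 1.2-fold lower number from compound 1 to compound 2 (0.07 log units; within the scatter) is within the scatter, so the two values cannot be told apart. Compound 3 gives 55000 nM, the highest of the three numbers; its gaps to compound 1 and to compound 2 both lie beyond the scatter. How the core of compound 3 differs from the core of compound 1 is not broken down here.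

Compound 4, `CCOc1ccccc1C[C@H]1COC[C@@H]1Cc1ccc(Cl)c(Cl)c1`, has not been measured in this assay. It differs from compound 3 by methyl in place of hydrogen on a saturated chain carbon bound to an oxygen on an aromatic ring. Among the compounds with values here, this is the same kind of change as the one from compound 1 to compound 2, but not the same: there the added carbon sits on a saturated chain carbon bound to an aromatic carbon, here on a saturated chain carbon bound to an oxygen on an aromatic ring. Within the data shown here, because the one measured step of this kind, a 1.2-fold lower number from compound 1 to compound 2 (0.07 log units; within the scatter), lay within the scatter, the expected step of a 1.1-fold lower number from compound 3 to compound 4 (0.04 log units; within the scatter) in this assay is also small. Compound 4 is therefore estimated at 50000 nM, with a range from 22000 nM to 110000 nM, which rests on one pair only and is uncertain.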

Compound 4, half-maximal effective concentration: 29000 nM
Compound 4: middle estimate off by 1.7-fold (0.24 log units), on the high side; measured number inside the range.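

In this assay, methyl in place of hydrogen on a saturated chain carbon bound to an oxygen on an aromatic ring gives a 1.9-fold lower number from compound 3 to compound 4 (0.28 log units; within the scatter), so the methoxy and ethoxy compounds cannot be told apart on this read-out. Set beside the earlier step, the added carbon shows no measurable difference between the two cores: the same change on two cores in this assay, a 1.2-fold lower number (0.07 log units; within the scatter) from compound 1 to compound 2 and a 1.9-fold lower number (0.28 log units; within the scatter) from compound 3 to compound 4, 1.6-fold (0.20 log units) apart, within the scatter of two such steps This shows only that in these two pairs the change stayed within the scatter on both cores; it does not show that the step would stay this small on any further core, and the two pairs also differ in where the methyl enters, so any influence of the core cannot be separated from that of the place.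

The compounds shown leave open whether a longer chain in place of the ethoxy's ethyl, or an amine or a carboxylic acid at the end of that chain, would move the number beyond the scatter. They also leave open whether methoxy to ethoxy would behave in the same way on the core of compound 1, which carries neither group.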